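A few compounds are considered here, and "the series" means these few. Any claim that something is new, unique, unknown or untested is made for them only; others in the source may bear on it.

Compound 2 `COC[C@H](C(C)C)C(c1ccc(O)c(OC)c1)c1ccc(O)c(OC)c1` stands at the top of the two numbers read in a functional assay on HeLa cells (Homo sapiens) for cytotoxicity, read by WST assay, with a stated time of 48 h; on this read-out lower numbers stand for stronger inhibition and higher numbers for weaker inhibition: in this assay compound 2 gives 76000 nM. Its nearest neighbour is compound 1 `COC[C@H](C)[C@H](C)C(c1ccc(O)c(OC)c1)c1ccc(O)c(OC)c1`, which in this assay gives 72000 nM, and the step of a 1.1-fold higher number from compound 1 to compound 2 (0.02 log units; within the scatter) separates the two by nothing that can be told from repeat measurement. Compound 3 `COc1cc(C(c2ccc(O)c(OC)c2)[C@@H](C)[C@H](C)CO)ccc1O` returns only a limit of the assay, > 100000 nM. The steps of an at least 1.3-fold higher number from compound 1 to compound 3 (0.14 log units; that floor lies within the scatter) and an at least 1.3-fold higher number from compound 2 to compound 3 (0.11 log units; that floor lies within the scatter) therefore carry floors that do not rise above the scatter either, and the same is true of the limit of > 100000 nM in this assay, at which 1 of the 3 values shown sits.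

Compound 4 `COc1cc(C(c2ccc(O)c(OC)c2)[C@H](CC(C)C)C(C)C)ccc1O` differs from compound 2 by isopropyl in place of methoxy on a saturated chain carbon, three bonds along the chain from two aromatic carbons. Within the data shown here, no measured step exchanges the methoxy for an alkyl group; the step of an at least 1.3-fold higher number from compound 2 to compound 3 (0.11 log units; that floor lies within the scatter) alters the same part of the chain, but only to a limit, and the step of a 1.1-fold higher number from compound 1 to compound 2 (0.02 log units; within the scatter) rearranges the chain without moving the number. Every change seen so far in this assay has left the read-out roughly where it was, so compound 4 is expected to do the same. Compound 4 is estimated at 70000 nM, within 30000 nM to 150000 nM. The expected step of a 1.1-fold lower number from compound 2 to compound 4 (0.04 log units; within the scatter) is thus no larger than the scatter.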

Compound 4, half-maximal inhibitory concentration: 8200 nM
For compound 4 the middle estimate is 8.5-fold (0.93 log units) above the measured one; measured number below the stated range.
By their numbers in this assay, from the lowest: compound 4; then compounds 1 and 2 (each within the scatter of the next). At a limit, above all of these: compound 3.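

In this assay, among these compounds, the saturated chain carbon three bonds along the chain from two aromatic carbons turns out to be a place where a single change moves the read-out: with isopropyl in place of methoxy, there is a 9.3-fold lower number from compound 2 to compound 4 (0.97 log units; beyond the scatter), whereas no earlier step had cleared the scatter. The wider comparison on the saturated chain carbon bound to two aromatic carbons agrees, with 1-isopropyl-3-methylbutyl in place of 2-(methoxymethyl)-1-methylpropyl giving an 8.8-fold lower number from compound 1 to compound 4 (0.94 log units; beyond the scatter), a step of similar size to the first. The change to the same group from 2-(hydroxymethyl)-1-methylpropyl gives an at least 12-fold lower number from compound 3 to compound 4 (1.08 log units; beyond the scatter), which also lies beyond the scatter but starts from a limit of the assay and so is only a floor: the limit of > 100000 nM in this assay, at which 1 of the 4 values shown sits.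

The compounds shown do not separate the loss of the methoxy oxygen from the arrival of the branched isopropyl carbons, as both happen in the one step. As far as these compounds go, how a methyl or ethyl group, an amine, a carboxylic acid or a longer chain at this place would read in this assay remains open.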